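Cyano for isopropyl in a narrow cytotoxicity series

The source may hold more compounds than are shown below. What is called first, only, known or untested is meant among the compounds shown, and "the series" means these compounds.

Compound 1 `CC(C)=CCOc1cc(Nc2nccs2)ccc1C` measured at 17000 nM
Compound 2 `CCc1ccc(Nc2nccs2)cc1OCC=C(C)C` measured at 31000 nM
Compound 3 `CC(C)=CCOc1cc(Nc2nccs2)ccc1C(C)C` measured at 31000 nM

All three compounds were tested in a functional assay on MT2 cells (Homo sapiens) for cytotoxicity, read by MTT assay (a higher number here means that more compound is tolerated, a lower number that less compound is tolerated), and their numbers lie close together. Compound 3 stands level with compound 2, as the record of no change at the digits printed from compound 2 to compound 3 (within the scatter) shows, and it also remains close to compound 1, with a 1.8-fold higher number from compound 1 to compound 3 (0.26 log units; within the scatter) as the measured gap.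

Compound 4 `CC(C)=CCOc1cc(Nc2nccs2)ccc1C#N` has not yet been measured. The change cyano in place of isopropyl on an aromatic carbon puts cyano in place of isopropyl on an aromatic carbon, ortho to a (3-methylbut-2-en-1-yl)oxy group and para to a (1,3-thiazol-2-yl)amino group.

All three measured steps alter the group at this same place, and the third of them is a 1.8-fold higher number from compound 1 to compound 2 (0.26 log units; within the scatter) in size, so none leaves the scatter. Within the data shown here, no measured compound carries cyano, which limits this evidence and widens the range. The expected result is a 1.3-fold lower number from compound 3 to compound 4 (0.11 log units; within the scatter) and so no step beyond the scatter is anticipated. Compound 4 is estimated at 24000 nM with an expected range from 9000 nM to 60000 nM in this assay overall.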

Compound 4, half-maximal cytotoxic concentration: 750 nM
The estimate for compound 4 lay 32-fold (1.51 log units) above the measured number; measured number below the stated range.
By their numbers in this assay, from the lowest: compound 4; then compounds 1, 2 and 3 (each within the scatter of the next).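

In this assay, the position proves far less indifferent than the alkyl series suggested: methyl, ethyl and isopropyl stay within the scatter of one another, whereas cyano gives a 41-fold lower number from compound 3 to compound 4 (1.62 log units; beyond the scatter), a 41-fold lower number from compound 2 to compound 4 (1.62 log units; beyond the scatter) and a 23-fold lower number from compound 1 to compound 4 (1.36 log units; beyond the scatter). Among these compounds, the large change therefore appears only on moving from these alkyl groups to cyano, the one group here with a triple bond and a hydrogen-bond acceptor, and the size of the alkyl group leaves no reading beyond the scatter. Nothing available here accounts for this drop.

The compounds shown leave open whether the low number is particular to cyano or would recur with an amine or a carboxylic acid at this place. From the compounds shown here alone, every compound also carries the (3-methylbut-2-en-1-yl)oxy group, so it remains open whether cyano would give a similar step with a benzyl group in its place.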